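Pyrazole ureas: phenol versus methyl ether at the aryl oxygen

The source may report more compounds than this note shows. Statements on the series, on what has been measured and on what is new or still open speak of the compounds shown alone.

Measured so far in a functional assay on UACC-257 cells (Homo sapiens) for inhibition, read by sulforhodamine B assay, with a stated time of 48 h; a lower number here means a stronger inhibitor of growth, a higher number a weaker inhibitor of growth:
compound 1 `O=C(Nc1cccc(-n2cc(-c3ccncc3)c(-c3ccc(Cl)c(O)c3)n2)c1)Nc1cccc(C(F)(F)F)c1`: 19100 nM
compound 2 `O=C(Nc1cccc(-n2cc(-c3ccncc3)c(-c3ccc(Cl)c(O)c3)n2)c1)Nc1ccc(Cl)c(Cl)c1`: 3160 nM
compound 3 `COc1cc(-c2nn(-c3cccc(NC(=O)Nc4ccc(Cl)c(C(F)(F)F)c4)c3)cc2-c2ccncc2)ccc1Cl`: 6030 nM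

Compound 3 carries the 4-chloro-3-methoxyphenyl group on the shared core and, on the urea, a 4-chloro-3-(trifluoromethyl)phenyl group. In this assay compound 3 stands second of the three numbers, within the scatter of compound 2 and beyond it from compound 1. For the measured compounds named here, the only step between measured compounds is on the urea aryl: a 6.0-fold lower number from compound 1 to compound 2 (0.78 log units; beyond the scatter).

Compound 4 `O=C(Nc1cccc(-n2cc(-c3ccncc3)c(-c3ccc(Cl)c(O)c3)n2)c1)Nc1ccc(Cl)c(C(F)(F)F)c1` differs from compound 3 in one place: hydrogen in place of methyl on an oxygen on an aromatic ring. Going by the values given here, the resulting 4-chloro-3-hydroxyphenyl group is the one present in compound 1 and compound 2, so compound 4 pairs that group with the urea aryl of compound 3. Among the compounds with values here, no measured pair shows the methyl-to-hydrogen change on the oxygen in isolation; the data contain no step on which to lean for it. The urea aryl of compound 4 lies between those of compound 2 and compound 1, whose values bracket the series. Compound 4 is therefore expected near compound 3, with the step of a 1.3-fold lower number from compound 3 to compound 4 (0.13 log units; within the scatter) not beyond the scatter. The estimate for compound 4 is 4500 nM, with a range of 1500 nM to 14000 nM.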

Compound 4, concentration for total growth inhibition: 2100 nM
For compound 4 the middle estimate is 2.1-fold (0.33 log units) above the measured one; low and high end bracket the measured number.
By their numbers in this assay, from the lowest: compounds 4, 2 and 3 (each within the scatter of the next, the first and the last beyond it); then compound 1.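

Replacing methyl with hydrogen on the oxygen can now be read in isolation: in this assay the step is (a 2.9-fold lower number from compound 3 to compound 4 (0.46 log units; beyond the scatter)), so with this urea aryl the 4-chloro-3-hydroxyphenyl group gives a lower number than the 4-chloro-3-methoxyphenyl group. With the hydroxy group held fixed, the urea aryl also gains two further readings: trifluoromethyl in place of chloro gives (a 1.5-fold lower number from compound 2 to compound 4 (0.18 log units; within the scatter)), which does not separate the two groups, whereas chloro in place of hydrogen gives (a 9.1-fold lower number from compound 1 to compound 4 (0.96 log units; beyond the scatter)), the largest of the three new steps. Nothing measured on these compounds bears on the origin of any of these steps.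

As far as these compounds go, the methoxy-to-hydroxy reading rests on a single pair, so its size on the urea aryls of compound 1 and compound 2 remains open. Also open, from the compounds shown here alone, is how other replacements at this position would read, such as an ethoxy group, an amine or a carboxylic acid in place of the hydroxy group.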